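This account rests on a few compounds, and the source may have more. Where it says the series, first, only, none or still open, it means among the compounds named here.

In a functional assay on HTB-54 cells (Homo sapiens) for cytotoxicity, read by MTT assay, with a stated time of 72 h (a lower number here means a stronger inhibitor of growth, a higher number a weaker inhibitor of growth), compound 1 `CCCCOC(=O)Nc1ccc([Se]C#N)cc1` gives 43400 nM. Compound 2 `Cc1ccc(OC(=O)Nc2ccc([Se]C#N)cc2)cc1` gives 44200 nM in this assay; the two numbers lie within the usual scatter of each other, so compound 1 stands level with compound 2 on the numbers shown, with no difference established. Compound 3 `N#C[Se]c1ccc(NC(=O)OCc2ccccc2)cc1` has not yet been measured in this assay. It differs from compound 1 by phenyl in place of propyl on a saturated chain carbon bound to an oxygen next to a carbonyl group. Among the compounds with values here, no measured step of this kind exists, and the two measured numbers give no direction, so a step within the scatter is expected, in either direction. Compound 3 is expected to give 40000 nM in this assay, between 18000 nM and 90000 nM, which means an expected step of a 1.1-fold lower number from compound 1 to compound 3 (0.04 log units; within the scatter).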

Compound 3, concentration for total growth inhibition: 50800 nM
The estimate for compound 3 lay 1.3-fold (0.10 log units) below the measured number; the range from low to high includes it.
By their numbers in this assay, from the lowest: compounds 1, 2 and 3 (each within the scatter of the next).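

Phenyl in place of propyl on a saturated chain carbon bound to an oxygen next to a carbonyl group gives a 1.2-fold higher number from compound 1 to compound 3 (0.07 log units; within the scatter) in this assay and so establishes no change. This first measured step at this position shows that a six-membered aromatic ring of carbon only can stand there in place of the propyl chain, with the number staying within the scatter.

Open, as far as these compounds go, is whether an amine, a carboxylic acid or a longer chain at this position would give a step beyond the scatter. Nothing available accounts for the size of this step.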